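Ethynyl for bromo on a sulfonamide aryl ring

The source may report more compounds than this note shows. Statements on the series, on what has been measured and on what is new or still open speak of the compounds shown alone.

Compound 1, `CC(=O)Nc1nc(-c2cccc(NS(=O)(=O)c3cccc(Br)c3)c2)cs1`, was tested in a functional assay on A-375 cells (Homo sapiens) for antiproliferative activity, read by trypan blue exclusion, with a stated time of 48 h, tested at 1 uM (a higher number here means a weaker effect of the compound at the concentration tested, a lower number a stronger effect), where the result for compound 1 is recorded as "not active" (no number reported), without a single number. A second compound from the same set, compound 2, `CC(=O)Nc1nc(-c2cccc(NS(=O)(=O)c3ccc(C#CCCc4ccccc4)cc3)c2)cs1`, gives 11.5% in this assay, a strong effect at the concentration tested. Compound 3, `C#Cc1cccc(S(=O)(=O)Nc2cccc(-c3csc(NC(C)=O)n3)c2)c1`, has not yet been measured. Relative to compound 1, the change in compound 3 is ethynyl in place of bromo on an aromatic carbon. Going by the values given here, with no step between measured compounds recorded, the size of the effect is uncertain; compound 2 shows that a carbon chain holding a triple bond on this ring can go with a strong effect, while compound 1 shows no effect, so a step toward a stronger effect than compound 1 is expected, though smaller than the gap to compound 2. Compound 3 is estimated to give 65% in this assay, within a range from 25% to 100%.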

Compound 3, a percentage reported as activity, at one concentration (the size of the read-out at that concentration, not a potency): 74.3%
Beside the measured number, compound 3's estimate is 9.3 percentage points below it, within the range that was stated.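

No step can be read from compound 1 to compound 3: in this assay compound 1 is recorded as "not active" (no number reported) and carries no number to set against compound 3 at 74.3% here. Nothing measured here speaks to a cause. From the compounds shown here alone, how far ethynyl in place of bromo shifts the effect stays open.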